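Ethyl to Isopropyl Ester on the Triazole-Fused Core

The source may report more compounds than this note shows. Statements on the series, on what has been measured and on what is new or still open speak of the compounds shown alone.

Compound 3 `CCOC(=O)C1=C(C)Nc2ncnn2C1c1ccoc1` gives 602 nM in an assay on HEK293 cells for displacement of a labelled ligand from adenosine receptor A2b (Homo sapiens), with a stated time of 30 min (on this read-out higher numbers stand for weaker inhibition and lower numbers for stronger inhibition), the second highest of the three numbers shown. Compound 1 `CCOC(=O)C1=C(C)NC(=O)CC1c1ccco1` gives 2540 nM in this assay, a higher number, and compound 2 `CC1=C(C(=O)OC(C)C)C(c2ccco2)n2ccnc2N1` gives 85.6 nM, the lowest of the three. Compound 4 `CC1=C(C(=O)OC(C)C)C(c2ccoc2)n2ncnc2N1` differs from compound 3 only by methyl in place of hydrogen on a saturated chain carbon bound to an oxygen next to a carbonyl group and a saturated chain carbon. Within the data shown here, no measured pair isolates this ester change, so the expected step from compound 3 to compound 4 is small, if anything toward a lower number, and is estimated at a 1.7-fold lower number from compound 3 to compound 4 (0.24 log units; within the scatter), which does not go beyond the scatter. For compound 4 the expected value in this assay is 350 nM, with a range from 120 nM to 1000 nM.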

Compound 4, inhibition constant: 351 nM
Beside the measured number, compound 4's estimate is 1.0-fold (0.00 log units) below it; the measured number falls inside the stated range.
By their numbers in this assay, from the lowest: compound 2; then compounds 4 and 3 (each within the scatter of the next); then compound 1.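

Among these compounds, compounds 3 and 4 are the first measured pair to isolate ethyl to isopropyl at this ester, and in this assay the change gives a 1.7-fold lower number from compound 3 to compound 4 (0.23 log units; within the scatter) and so stays within the scatter. On this core, the added methyl on the saturated chain carbon bound to the ester oxygen therefore has no effect that can be told from the scatter. Nothing available explains this result. Still open, on these data alone, is whether a longer chain, a carboxylic acid or an amide at this position would keep the number, and whether ethyl to isopropyl reads the same on the cores of compound 1 and compound 2.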